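Trimming the Amide Substituent: Toward Compound 4

The source may report more compounds than this note shows. Statements on the series, on what has been measured and on what is new or still open speak of the compounds shown alone.

Compound 1 `COc1cc(-c2nn(-c3cccc(NC(=O)c4cccc(C(F)(F)F)c4)c3)cc2-c2ccncc2)ccc1Cl`: > 50000 nM
Compound 2 `COc1cc(-c2nn(-c3cccc(NC(=O)Nc4cccc(C(F)(F)F)c4)c3)cc2-c2ccncc2)ccc1Cl`: > 50000 nM
Compound 3 `COc1cc(-c2nn(-c3cccc(NC(=O)Nc4ccc(Cl)c(C(F)(F)F)c4)c3)cc2-c2ccncc2)ccc1Cl`: 14900 nM

Three compounds share one core and differ only in the group attached to the carbonyl carbon. In a functional assay on KM12 cells (Homo sapiens) for inhibition, read by sulforhodamine B assay, with a stated time of 48 h (on this read-out higher numbers stand for lower toxicity in this test and lower numbers for higher toxicity in this test), compound 1 reaches only a limit of the assay, > 50000 nM, and no number. In this assay compound 2 likewise gives only a limit, > 50000 nM. For the measured compounds named here, compound 3 is the one compound with a real number, 14900 nM, and so stands as the only fixed point here. The steps of an at least 3.3-fold lower number from compound 1 to compound 3 (0.52 log units; beyond the scatter) and an at least 3.3-fold lower number from compound 2 to compound 3 (0.52 log units; beyond the scatter) show that the chloro-bearing urea of compound 3 is what brought the number within reach.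

Compound 4 `COc1cc(-c2nn(-c3cccc(NC(=O)c4ccccc4)c3)cc2-c2ccncc2)ccc1Cl` goes the other way: phenyl in place of (4-chloro-3-(trifluoromethyl)phenyl)amino on a carbonyl carbon. This removes both the amino link and the chloro and trifluoromethyl groups, leaving a bare benzamide, closer to compound 1 than to compound 3. Given (the limit of > 50000 nM in this assay, at which 2 of the 3 values shown sit), the expected step is a 3.4-fold higher number from compound 3 to compound 4 (0.53 log units; beyond the scatter), back toward that limit. Compound 4 is therefore estimated at 50000 nM, within 20000 nM to 120000 nM.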

Compound 4, concentration lethal to 50% of the cells: > 100000 nM
Compound 4: only a limit was reported; the forecaster's own chance of this, stated with the estimate: 75%; middle value at least 2.0-fold (0.30 log units) from the limit.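

In this assay, replacing the substituted urea arm of compound 3 with a plain phenyl on the carbonyl carbon gives an at least 6.7-fold higher number from compound 3 to compound 4 (0.82 log units; beyond the scatter). Among the four compounds shown, only compound 3, which carries (4-chloro-3-(trifluoromethyl)phenyl)amino at this place, gives a real number, so a bare benzamide does not restore one. Compound 4 gives only a limit of the assay, and no number: the limit of > 100000 nM in this assay, at which 1 of the 4 values shown sits.

On these data alone, the steps to compound 4 from compound 1 and from compound 2 cannot be read, as both ends of each are limits, so any part played by the trifluoromethyl group alone stays unknown. Also open, as far as these compounds go, is whether a urea carrying only a chloro on its phenyl ring, or a methyl or an amine in place of that chloro, would give a real number.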